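Aryl replacement at the ring carbon bound to nitrogen

The compounds below may be only part of what the source reports. "The series", "measured", "known", "first", "only" and "open" are said of these compounds alone.

Measured in a functional assay on PC-3 cells (Homo sapiens) for cytotoxicity, read by sulforhodamine B assay, with a stated time of 48 h; on this read-out lower numbers stand for stronger inhibition and higher numbers for weaker inhibition:
compound 1, `C[C@H]1CC[C@@H]2[C@@H](OC(=O)[C@]23CC(c2ccccc2)=NO3)[C@]2(C)C(=O)C=C[C@@]12O`: 46000 nM
compound 2, `COc1ccc(C2=NO[C@]3(C2)C(=O)O[C@@H]2[C@H]3CC[C@H](C)[C@]3(O)C=CC(=O)[C@@]23C)cc1OC`: 25000 nM

Going by the values given here, the two numbers sit within the usual scatter of each other; the only recorded step, a 1.8-fold lower number from compound 1 to compound 2 (0.26 log units; within the scatter), therefore carries no reliable direction. Compound 2 is the reference for the next compound, compound 3, `Cc1ccc(C2=NO[C@]3(C2)C(=O)O[C@@H]2[C@H]3CC[C@H](C)[C@]3(O)C=CC(=O)[C@@]23C)cc1`. The change is 4-methylphenyl in place of 3,4-dimethoxyphenyl on a carbon with a double bond to nitrogen. Among the compounds with values here, the one step that bears on it is the aryl swap at the same carbon with a double bond to nitrogen, a 1.8-fold lower number from compound 1 to compound 2 (0.26 log units; within the scatter), which stayed within the scatter. Within the data shown here, nothing so far shows the aryl group moving the number beyond the scatter, so no step beyond it is expected in this assay for compound 3. The step of a 1.3-fold higher number from compound 2 to compound 3 (0.11 log units; within the scatter) is the expected size. Compound 3 is estimated at 32000 nM, with a range from 12000 nM to 80000 nM.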

Compound 3, half-maximal inhibitory concentration: 14000 nM
Compound 3: middle estimate off by 2.3-fold (0.36 log units), on the high side; low and high end bracket the measured number.
By their numbers in this assay, from the lowest: compounds 3, 2 and 1 (each within the scatter of the next, the first and the last beyond it).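

In this assay, going by these compounds alone, the step of a 3.3-fold lower number from compound 1 to compound 3 (0.52 log units; beyond the scatter) is the first to lie beyond the scatter, and the change is methyl in place of hydrogen on an aromatic carbon. The aryl group on the carbon with a double bond to nitrogen can therefore shift the number, though only modestly. The step of a 1.8-fold lower number from compound 2 to compound 3 (0.25 log units; within the scatter) stays within the scatter, so 4-methylphenyl and 3,4-dimethoxyphenyl cannot be ranked here, despite their different counts of hydrogen-bond acceptors; no supporting data bear on either step.

On these data alone, whether the methyl result reflects a wider trend remains open, since it rests on a single comparison. An amine, a carboxylic acid or a longer chain in place of that methyl could show whether this position allows a larger step.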